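The source may hold more compounds than are shown below. What is called first, only, known or untested is meant among the compounds shown, and "the series" means these compounds.

Compound 3 `NC(=O)[C@@H](CCC(F)(F)F)N(C[C@@H]1CCCOC1)S(=O)(=O)c1ccc(Cl)cc1` is the compound under study in an in vitro ADME assay on microsomes from liver (Homo sapiens) for metabolic stability, read by HPLC (a higher number here means faster removal of the compound, a lower number slower removal), where compound 3 gives 136 mL/min/kg. Among the two numbers shown it sits highest; its nearest neighbour is compound 1 `CC1(C)C[C@@H](CN([C@H](CCC(F)(F)F)C(N)=O)S(=O)(=O)c2ccc(Cl)cc2)O1`, which in this assay gives 16.5 mL/min/kg, so the shift recorded is an 8.2-fold higher number from compound 1 to compound 3 (0.92 log units; beyond the scatter). Compound 2 `CC1(C)CO[C@@H]1CN([C@H](CCC(F)(F)F)C(N)=O)S(=O)(=O)c1ccc(Cl)cc1` gives only a limit in this assay, > 293 mL/min/kg. One value among the three is such a limit (the limit of > 293 mL/min/kg in this assay, at which 1 of the 3 values shown sits), which is why the shift an at least 2.1-fold lower number from compound 2 to compound 3 (0.33 log units; beyond the scatter) can be stated only as a bound, as can an at least 17-fold higher number from compound 1 to compound 2 (1.24 log units; beyond the scatter).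

Compound 4 `NC(=O)[C@@H](CCC(F)(F)F)N(C[C@H]1CCO1)S(=O)(=O)c1ccc(Cl)cc1` differs from compound 3 in one place: oxetan-2-yl in place of oxan-3-yl on a saturated chain carbon bound to a sulfonamide nitrogen. The two measured steps that bear on this change point in opposite directions. Going from a 4,4-dimethyloxetan-2-yl ring to oxan-3-yl raised the number, as in an 8.2-fold higher number from compound 1 to compound 3 (0.92 log units; beyond the scatter), while going from 3,3-dimethyloxetan-2-yl to oxan-3-yl lowered it by at least a modest amount, as in an at least 2.1-fold lower number from compound 2 to compound 3 (0.33 log units; beyond the scatter). The unsubstituted oxetan-2-yl of compound 4 carries neither pair of methyl groups, so the expected step is small and uncertain, leaning slightly upward. Compound 4 is therefore expected to give about 170 mL/min/kg, with a likely span from 60 mL/min/kg to 400 mL/min/kg. That estimate corresponds to an expected 1.3-fold higher number from compound 3 to compound 4 (0.10 log units; within the scatter).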

Compound 4, clearance: 63.8 mL/min/kg
Compound 4: the middle estimate sits 2.7-fold (0.43 log units) above what was measured, within the range that was stated.
By their numbers in this assay, from the lowest: compound 1; then compound 4; then compound 3. At a limit, above all of these: compound 2.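

Compound 4 supplies the plain ring that the two dimethyl compounds can be read against, and in this assay the place of the methyl pair decides the direction of the change: going from 4,4-dimethyloxetan-2-yl to oxetan-2-yl gives a 3.9-fold higher number from compound 1 to compound 4 (0.59 log units; beyond the scatter), while going from 3,3-dimethyloxetan-2-yl to oxetan-2-yl gives an at least 4.5-fold lower number from compound 2 to compound 4 (0.66 log units; beyond the scatter). Compound 2 gives a limit and not a number, so the second of these steps is only a bound: the limit of > 293 mL/min/kg in this assay, at which 1 of the 4 values shown sits. The plain four-membered ring also shows that ring choice matters here without any methyl groups, with a 2.1-fold lower number from compound 3 to compound 4 (0.33 log units; beyond the scatter), although this step changes ring size and the ring carbon that carries the chain together.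

The compounds shown leave open whether ring size or the point of attachment drives that last step, which oxetan-3-yl or oxan-2-yl would help to separate. They also leave open whether the ring oxygen matters at all, which cyclobutyl would test, and whether a single methyl group on the oxetan-2-yl ring would act as the pairs do.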